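Hexyl to Trifluoromethyl: Expected Read-out for Compound 3

The compounds below may be only part of what the source reports. "The series", "measured", "known", "first", "only" and "open" are said of these compounds alone.

Compound 1 `CC(C)c1ccc(NC(=O)N[C@H](C)c2ccccc2)cc1`: 99%
Compound 2 `CCCCCCc1ccc(NC(=O)N[C@H](C)c2ccccc2)cc1`: 100%

In an ADME assay on the whole organism with Oryza sativa as the target, tested at 0.1 uM (on this read-out lower numbers stand for a stronger effect and higher numbers for a weaker effect at the one concentration tested), compound 2 holds the higher of the two numbers, yet the step of a number 1 percentage points higher from compound 1 to compound 2 (within the scatter) lies within the scatter, so the two compounds are not told apart. Compound 3 `C[C@@H](NC(=O)Nc1ccc(C(F)(F)F)cc1)c1ccccc1` differs from compound 2 by trifluoromethyl in place of hexyl on an aromatic carbon. Among the compounds with values here, only the step of a number 1 percentage points higher from compound 1 to compound 2 (within the scatter) bears on this change, and it was within the scatter, so no step beyond the scatter is expected in this assay for compound 3. Compound 3 is therefore estimated at 98%, between 85% and 100%, an expected step of a number 2 percentage points lower from compound 2 to compound 3 (within the scatter).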

Compound 3, a percentage reported as activity, at one concentration (the size of the read-out at that concentration, not a potency): 93%
For compound 3 the middle estimate is 5 percentage points above the measured one; the range from low to high includes it.
By their numbers in this assay, from the lowest: compounds 3, 1 and 2 (each within the scatter of the next).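

In this assay, the aromatic carbon para to a large group now carries trifluoromethyl, a group with fluorine, instead of a group of carbon alone. With a number 7 percentage points lower from compound 2 to compound 3 (within the scatter) and a number 6 percentage points lower from compound 1 to compound 3 (within the scatter) the read-out still does not separate the compounds, so hexyl, isopropyl and trifluoromethyl show no difference beyond the scatter at this position. No measured evidence bears on this result.

As far as these compounds go, whether an amine or a carboxylic acid at this position would move the read-out beyond the scatter remains open.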